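Propylsulfonyl against methoxymethyl on the fluoro-bearing ring

The compounds below may be only part of what the source reports. "The series", "measured", "known", "first", "only" and "open" are said of these compounds alone.

Measured so far:
compound 1 `CCCS(=O)(=O)c1cccc(C#Cc2cc(Cl)ccc2OCC(=O)O)c1`: 9 nM
compound 2 `COCc1ccc(F)c(C#Cc2cc(Cl)ccc2OCC(=O)O)c1`: 72 nM

In an assay on CHO cells for displacement of a labelled ligand from prostaglandin D2 receptor 2 (Homo sapiens), read by scintillation counting (on this read-out lower numbers stand for stronger inhibition and higher numbers for weaker inhibition), compound 1 gives 9 nM and compound 2 gives 72 nM. For the measured compounds named here, of the two numbers, compound 2 holds the higher one, and the gap to compound 1 lies beyond the usual scatter; no single-change step between these two has been worked out, so the pair is read only as two values.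

Compound 3 `CCCS(=O)(=O)c1ccc(F)c(C#Cc2cc(Cl)ccc2OCC(=O)O)c1` is the next member, not yet measured. Relative to compound 2 the change is propylsulfonyl in place of methoxymethyl on an aromatic carbon. Going by the values given here, the propylsulfonyl group is the one that compound 1 carries, and in this assay compound 1 sits at 9 nM, well under compound 2. On that basis a step downward, beyond the scatter, is expected from compound 2 to compound 3, of about a 6.0-fold lower number from compound 2 to compound 3 (0.78 log units; beyond the scatter). For compound 3 the estimate in this assay is 12 nM, with a range from 4 nM to 40 nM.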

Compound 3, inhibition constant: 3.4 nM
Estimate against measurement, compound 3: 3.5-fold (0.55 log units) above, and the stated range ends above it.
By their numbers in this assay, from the lowest: compound 3; then compound 1; then compound 2.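

Working notes: in this assay the step of a 21-fold lower number from compound 2 to compound 3 (1.33 log units; beyond the scatter) is the first single-place reading of propylsulfonyl in place of methoxymethyl, on the aromatic carbon para to a fluoro group, and it is large. With propylsulfonyl held constant, fluoro in place of hydrogen gives a 2.6-fold lower number from compound 1 to compound 3 (0.42 log units; beyond the scatter) and is a modest change beyond the scatter, so the fluoro group does not cost affinity in this pair and the larger of the two steps belongs to the propylsulfonyl exchange. Nothing measured here accounts for either step.

Open, as far as these compounds go, is whether the fluoro step carries over when methoxymethyl occupies this position. Also open, from the compounds shown here alone, is whether a methylsulfonyl group, a sulfonamide or a longer chain on the sulfonyl would match propylsulfonyl here.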